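The compounds below may be only part of what the source reports. "The series", "measured", "known", "first", "only" and "open" are said of these compounds alone.

Compound 1 `COc1cc(/C=C/C(=O)Nc2ccc(NC(=O)[C@@H](O)[C@H](N)CC3CCCCC3)cc2C)cc(OC)c1OC`: 1800 nM
Compound 2 `CCOc1ccc(/C=C/C(=O)Nc2ccc(NC(=O)[C@@H](O)[C@H](N)CC3CCCCC3)cc2)cc1`: 1000 nM
Compound 3 `COc1cc(/C=C/C(=O)Nc2ccc(NC(=O)[C@@H](O)[C@H](N)CC3CCCCC3)cc2)cc(OC)c1OC`: 670 nM; 2000 nM (2 entries)

All three compounds were tested in a functional assay on HUVEC cells (Homo sapiens) for antiproliferative activity; on this read-out lower numbers stand for stronger inhibition of growth and higher numbers for weaker inhibition of growth. Compound 2 and compound 1 lie within the usual scatter of each other. Compound 3 has no single number, as its repeated entries show: the several entries of compound 3 in this assay, 670 nM; 2000 nM (2 entries). Compound 4 `CCOc1ccc(/C=C/C(=O)Nc2ccc(NC(=O)[C@@H](O)[C@H](N)CCc3ccccc3)cc2)cc1` differs from compound 2 in one place, with benzyl in place of cyclohexyl on a saturated chain carbon, two bonds along the chain from an amine nitrogen. Among the compounds with values here, no pair of measured compounds shows this change, so only a small step that stays within the scatter is expected. The expected change is a 1.2-fold higher number from compound 2 to compound 4 (0.08 log units; within the scatter). For compound 4 the estimated value is 1200 nM, with an expected range of 400 nM to 3500 nM.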

Compound 4, concentration for 50% growth inhibition: 1800 nM
Compound 4: the middle estimate sits 1.5-fold (0.18 log units) below what was measured, within the range that was stated.
By their numbers in this assay, from the lowest: compounds 2, 1 and 4 (each within the scatter of the next).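

At this position, a non-aromatic ring and an aromatic ring with one more carbon cannot be told apart in this assay: the change gives a 1.8-fold higher number from compound 2 to compound 4 (0.26 log units; within the scatter). Within the data shown here, this is the only step measured here, and it shows that this swap leaves the number within the scatter. Repeat measurements can themselves differ widely, as this line shows: the several entries of compound 3 in this assay, 670 nM; 2000 nM (2 entries)

As far as these compounds go, it remains open whether a ring is needed in this place at all, or whether a straight butyl chain would serve as well. A benzyl carrying a carboxylic acid also remains untested among the compounds shown.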